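Dichlorophenyl to dimethylphenyl, repeated on compound 3

The compounds below may be only part of what the source reports. "The series", "measured", "known", "first", "only" and "open" are said of these compounds alone.

Compound 1 `Cc1cccc(N2CCN(CCCNc3nc(NCc4ccco4)c4ccccc4n3)CC2)c1C`, compound 2 `Clc1cccc(N2CCN(CCCNc3nc(NCc4ccco4)c4ccccc4n3)CC2)c1Cl` and compound 3 `Clc1cccc(N2CCN(CCCCNc3nc(NCc4ccco4)c4ccccc4n3)CC2)c1Cl` have been run in a functional assay on HT-29 cells (Homo sapiens) for cytotoxicity, read by MTT assay, with a stated time of 2 days; a lower number here means a stronger inhibitor, a higher number a weaker inhibitor. Compound 1 gives 840 nM, compound 2 gives 3370 nM and compound 3 gives 3370 nM. The difference between the cores of compound 2 and compound 3 is not broken down here; their two values show no difference at the digits reported. The change 2,3-dimethylphenyl in place of 2,3-dichlorophenyl on an amine nitrogen in a ring gave a 4.0-fold lower number from compound 2 to compound 1 (0.60 log units; beyond the scatter). Compound 4 `Cc1cccc(N2CCN(CCCCNc3nc(NCc4ccco4)c4ccccc4n3)CC2)c1C` differs from compound 3 by the same change, (2,3-dimethylphenyl in place of 2,3-dichlorophenyl on an amine nitrogen in a ring), at a place described in the same words. For compound 4 the expected step is a 3.7-fold lower number from compound 3 to compound 4 (0.57 log units; beyond the scatter). For the measured compounds named here, that expectation rests on the single earlier step of a 4.0-fold lower number from compound 2 to compound 1 (0.60 log units; beyond the scatter) and on the starting point set by compound 3 at 3370 nM. Compound 4 is accordingly estimated at 900 nM, with a likely range from 400 nM to 2000 nM.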

Compound 4, half-maximal inhibitory concentration: 860 nM
For compound 4 the middle estimate is 1.0-fold (0.02 log units) above the measured one, and the stated range covers the measured number.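

In this assay, 2,3-dimethylphenyl in place of 2,3-dichlorophenyl gave a 3.9-fold lower number from compound 3 to compound 4 (0.59 log units; beyond the scatter). Set beside the earlier step, the change carries from one core to the other at a size that holds within the scatter: the same change on two cores in this assay, a 4.0-fold lower number (0.60 log units; beyond the scatter) from compound 2 to compound 1 and a 3.9-fold lower number (0.59 log units; beyond the scatter) from compound 3 to compound 4, 1.0-fold (0.01 log units) apart, within the scatter of two such steps. This shows transfer across these two cores in this one cell assay only; it does not show that the step would hold on a core that differs in another way, and it gives no reason for the step.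

Open, as far as these compounds go, is whether the step persists with a longer chain on the ring nitrogen. Also open is how methoxy or trifluoromethyl groups on the phenyl ring would compare with the two groups shown.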